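Octyl to phenyl on the aryl ether: compound 3

The compounds below may be only part of what the source reports. "The series", "measured", "known", "first", "only" and "open" are said of these compounds alone.

Measured so far:
compound 1 `CCCCCCCCc1ccc(OCC(=O)Cn2nnc(-c3ccc(Cl)cc3)n2)cc1` — 35 nM
compound 2 `CCCCCCCCc1ccc(OC(C)C(=O)Cn2nnc(-c3ccc(Cl)cc3)n2)cc1` — 35 nM

In an assay on microsomes from brain for inhibition of Fatty-acid amide hydrolase 1 (Rattus norvegicus), read by fluorescence and HPLC, with a stated time of 60 min (on this read-out higher numbers stand for weaker inhibition and lower numbers for stronger inhibition), compound 1 gives 35 nM and compound 2 gives 35 nM; the step of no change at the digits printed from compound 1 to compound 2 (within the scatter) lies within the scatter, so compound 2 stands level with compound 1.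

Compound 3 `CC(Oc1ccc(-c2ccccc2)cc1)C(=O)Cn1nnc(-c2ccc(Cl)cc2)n1` differs from compound 2 by phenyl in place of octyl on an aromatic carbon. Within the data shown here, no measured step touches this position: the one step known, no change at the digits printed from compound 1 to compound 2 (within the scatter), concerns the chain carbon and does not bear on an exchange of the octyl tail. Among the measured compounds shown here, the expectation for compound 3 in this assay rests on no precedent, and a modest loss is estimated, a 2.9-fold higher number from compound 2 to compound 3 (0.46 log units; beyond the scatter). Compound 3 is estimated at 100 nM, range 30 nM to 400 nM.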

Compound 3, half-maximal inhibitory concentration: 25 nM
Compound 3: middle estimate off by 4.0-fold (0.60 log units), on the high side; the whole stated range lies above it.
By their numbers in this assay, from the lowest: compounds 3, 1 and 2 (each within the scatter of the next).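

In this assay the aromatic carbon that bears the octyl tail also takes phenyl, with a 1.4-fold lower number from compound 2 to compound 3 (0.15 log units; within the scatter) as the step. At this position, then, the saturated octyl chain can be exchanged for one six-membered aromatic ring of carbon only without a change beyond the scatter. No available evidence accounts for the two groups reading alike. Open, from the compounds shown here alone, is whether a shorter chain, a longer chain or a carboxylic acid on this carbon would hold the same level. Also open, going by these compounds, is whether the methyl on the chain carbon remains without effect when phenyl stands on the aromatic ring.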